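Ethyl ester of the indole acid: an expected step

The compounds below may be only part of what the source reports. "The series", "measured", "known", "first", "only" and "open" are said of these compounds alone.

Measured so far:
Compound 1, `O=C(O)/C=C/c1ccncc1-c1ccc2cc[nH]c2c1`: 2.4 nM
Compound 2, `CCOC(=O)/C=C/c1ccncc1-c1ccc2c(ccn2C)c1`: 144 nM
Compound 3, `COC(=O)/C=C/c1ccncc1-c1ccc2ccccc2c1`: 40.6 nM

In an assay on a protein complex for inhibition of CDK8/Cyclin C (Homo sapiens), with a stated time of 1 h (a higher number here means a weaker inhibitor, a lower number a stronger inhibitor), compound 1 gives 2.4 nM and stands lowest of the three numbers. The nearest of the others is compound 3, whose value 40.6 nM lies beyond the scatter from it; compound 2, with 144 nM, lies further still. Compounds 2 and 3 each differ from compound 1 in more than one place, so their values show only that the two esters with altered cores read higher than the acid.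

Compound 4, `CCOC(=O)/C=C/c1ccncc1-c1ccc2cc[nH]c2c1`, has not yet been measured. It differs from compound 1 in one place: ethyl in place of hydrogen on an oxygen next to a carbonyl group. The carboxy of compound 1 thus becomes ethoxycarbonyl in compound 4.

For the measured compounds named here, no single-change step is available to anchor this move. Both esters already measured, compound 2 at 144 nM and compound 3 at 40.6 nM, read well above compound 1, so the move to the ethyl ester is expected to raise the number. On this basis the expected step is a 10-fold higher number from compound 1 to compound 4 (1.02 log units; beyond the scatter). Compound 4 is therefore estimated at 25 nM, within a range from 6 nM to 110 nM.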

Compound 4, half-maximal inhibitory concentration: 12.1 nM
The estimate for compound 4 lay 2.1-fold (0.32 log units) above the measured number; the measured number falls inside the stated range.
By their numbers in this assay, from the lowest: compound 1; then compound 4; then compound 3; then compound 2.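

In this assay, ethyl in place of hydrogen on an oxygen next to a carbonyl group gives a 5.0-fold higher number from compound 1 to compound 4 (0.70 log units; beyond the scatter). For the compounds shown here, this is the first step here in which nothing else changes, so the rise can be tied to carboxy becoming ethoxycarbonyl on the core of compound 1, and its modest size shows that compound 4, at 12.1 nM, keeps much of the reading of the acid without that hydrogen. Nothing shown gives a reason for this step.

The compounds shown leave open whether the rise follows from the loss of the hydrogen or from the ethyl itself, a question that a longer chain on that oxygen or an amide in place of the ester would bear on. They also leave open whether the same change would give a step of similar size on another core.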